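The compounds below may be only part of what the source reports. "The series", "measured", "known", "first", "only" and "open" are said of these compounds alone.

In an assay on isolated protein for binding affinity to 5-hydroxytryptamine receptor 6 (Homo sapiens) (a higher number here means a weaker inhibitor, a lower number a stronger inhibitor), compound 1 `COc1ccc(S(=O)(=O)Nc2cccc(Br)c2)cc1N1CCNCC1` gives 1.26 nM. Compound 2 `COc1ccc(S(=O)(=O)Nc2cccc(I)c2)cc1N1CCNCC1` gives 0.501 nM. Compound 3 `COc1ccc(S(=O)(=O)Nc2cc(Br)cc(Br)c2Br)cc1N1CCNCC1` gives 2.51 nM.

Compound 3 has the highest number of the three, which in this assay means the weakest binding of the set. Its number sits within the scatter of compound 1, so those two cannot be separated, while the gap to compound 2 is larger: a 5.0-fold higher number from compound 2 to compound 3 (0.70 log units; beyond the scatter). Compound 4 `COc1ccc(S(=O)(=O)Nc2cc(Cl)cc(Cl)c2Br)cc1N1CCNCC1` differs from compound 3 in one place: 2-bromo-3,5-dichlorophenyl in place of 2,3,5-tribromophenyl on a sulfonamide nitrogen. Going by the values given here, two measured steps bear on this change. The first, a 2.0-fold higher number from compound 1 to compound 3 (0.30 log units; within the scatter), and the second, a 5.0-fold higher number from compound 2 to compound 3 (0.70 log units; beyond the scatter), show what happened when a ring with one halogen was exchanged for the tribromophenyl ring. Among the compounds with values here, the only swap of one halogen for another among the measured compounds is a 2.5-fold lower number from compound 1 to compound 2 (0.40 log units; beyond the scatter), where iodo in place of bromo gave a lower number; exchanging bromo for chloro runs the other way along the same series, so if anything a small rise in the number is expected, but not one that should clear the scatter. Compound 4 is therefore expected to give 3.2 nM, with a range from 1.2 nM to 8.5 nM. The step this estimate implies is a 1.3-fold higher number from compound 3 to compound 4 (0.11 log units; within the scatter).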

Compound 4, inhibition constant: 3.16 nM
Compound 4: the middle estimate sits 1.0-fold (0.01 log units) above what was measured; low and high end bracket the measured number.
By their numbers in this assay, from the lowest: compound 2; then compounds 1, 3 and 4 (each within the scatter of the next, the first and the last beyond it).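

Putting 2-bromo-3,5-dichlorophenyl in place of 2,3,5-tribromophenyl on the sulfonamide nitrogen gives a 1.3-fold higher number from compound 3 to compound 4 (0.10 log units; within the scatter) in this assay, so on this ring chloro can stand in for bromo with no change that can be told from scatter. The new compound does add one thing: a 2.5-fold higher number from compound 1 to compound 4 (0.40 log units; beyond the scatter) lies beyond the scatter, as does a 6.3-fold higher number from compound 2 to compound 4 (0.80 log units; beyond the scatter), so compound 4 can be separated from both rings carrying a single halogen, whereas compound 3 could not be separated from compound 1. No measurement here offers a reason for these differences among the halogenated rings, so the numbers describe what happens without explaining it.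

All the rings shown carry only bromo, chloro or iodo, so it remains open whether a halogen is needed at all on this ring, a question that methyl, methoxy or a nitrile in its place would address. As far as these compounds go, it also remains open how the number would respond if the ring held a carboxylic acid or an amine, or if the shared core itself were changed.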